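From an Ethyl Group to a Nitrogen-Rich Replacement

This account rests on a few compounds, and the source may have more. Where it says the series, first, only, none or still open, it means among the compounds named here.

Of the compounds shown here, three built on a shared core have been tested in a functional assay on the whole organism (blood, strain albino) with Mus musculus as the target, with stated times of 6 days and 4 h, at a dose of 0.4 mmol/kg by the oral route; on this read-out higher numbers stand for more inhibition at the one dose given (going by the name of the read-out) and lower numbers for less inhibition. Compound 1 `Cc1cc(C(=O)O)nn1-c1ccc(S(=O)(=O)NC(=S)NCc2ccccc2)cc1` carries a benzyl group on an amide-type nitrogen. In this assay compound 1 reaches only a limit of the assay, < 2%. Compound 2 `Cc1cc(C(=O)O)nn1-c1ccc(S(=O)(=O)NC(=S)NC2CCCCC2)cc1` carries a cyclohexyl group in that place, and in this assay compound 2 gives 1%. Because of the limit of < 2% in this assay, at which 1 of the 3 values shown sits, the step that the limit leaves unreadable from compound 1 to compound 2 cannot be sized. Compound 3 `CCNC(=O)NS(=O)(=O)c1ccc(-n2nc(C)cc2C)cc1` carries an ethyl group on an amide-type nitrogen whose other neighbour is a carbonyl carbon. In this assay compound 3 sits at a limit of the assay, < 1%, so it stands at the floor of what the read-out can report.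

Compound 4 `Cc1cc(C)n(-c2ccc(S(=O)(=O)NC(=O)NNC(=N)N)cc2)n1` differs from compound 3 in one place: a group of 4 heavy atoms (1 carbon, 3 nitrogen; no ring) in place of a group of 2 heavy atoms (2 carbon; no ring), on an amide-type nitrogen. Within the data shown here, no measured step changes a group on this nitrogen in a comparable way, and the only measured step on an amide-type nitrogen is the unreadable one already described. With all three measured values resting at or next to the floor, as the limit of < 1% in this assay, at which 1 of the 3 values shown sits, and the limit of < 2% in this assay, at which 1 of the 3 values shown sits, show, no step beyond the scatter is expected, and the expected step of a number at least 1 percentage points higher from compound 3 to compound 4 (that floor lies within the scatter) is small. Compound 4 is therefore expected to give about 2% in this assay, within 0% to 10%, quite possibly reported only as a limit again.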

Compound 4, a percentage reported as inhibition, in the whole organism at one dose (the size of the read-out at that dose, not a potency): 3%
The estimate for compound 4 lay 1 percentage points below the measured number, within the range that was stated.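

Replacing the ethyl group with the group of 4 heavy atoms (1 carbon, 3 nitrogen; no ring), on an amide-type nitrogen whose other neighbour is a carbonyl carbon, gives in this assay a number at least 2 percentage points higher from compound 3 to compound 4 (that floor lies within the scatter). This is the first readable step among the compounds shown, and it shows that a change at this position, bringing in hydrogen-bond donors and an acceptor where ethyl has none, does not move the read-out beyond the usual scatter. The step can be given only as a floor because compound 3 rests on a limit: the limit of < 1% in this assay, at which 1 of the 4 values shown sits.

Going by these compounds, whether a simple amine or a longer chain such as hexyl on this nitrogen would lift the read-out clear of the floor stays open. Each compound is also seen at a single oral dose, so the values shown say nothing about how any of them would behave at a higher dose, and the unreadable step between compound 1 and compound 2 adds nothing to this.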